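Cytotoxicity Outlook for a Difluoropyridinyl Analogue

This account rests on a few compounds, and the source may have more. Where it says the series, first, only, none or still open, it means among the compounds named here.

Three compounds, compound 1 `O=[N+]([O-])c1cn2c(n1)OC(COc1ccc(-c3ccc(F)cc3F)cn1)CC2`, compound 2 `CC1(COc2cccc(-c3ccc(F)cc3)n2)CCn2cc([N+](=O)[O-])nc2O1` and compound 3 `O=[N+]([O-])c1cn2c(n1)OC(COc1ccc(-c3ccc(F)nc3F)nc1)CC2`, have been tested in an ADME assay on MRC5 cells (Homo sapiens) for cytotoxicity, read by resazurin assay, with a stated time of 72 h; a higher number here means a weaker inhibitor, a lower number a stronger inhibitor. Compound 1 gives > 64000 nM, which is a limit of the assay rather than a number. Compound 2 gives > 64000 nM, again only a limit. Compound 3 likewise gives > 64000 nM, a limit. Among the measured compounds shown here, compound 2 therefore stands where every value so far sits: the limit of > 64000 nM in this assay, at which 3 of the 3 values shown sit. Compound 4 `CC1(COc2cccc(-c3ccc(F)nc3F)n2)CCn2cc([N+](=O)[O-])nc2O1` is built from compound 2 by one change: 2,6-difluoropyridin-3-yl in place of 4-fluorophenyl on an aromatic carbon. Compound 3 already carries the 2,6-difluoropyridin-3-yl group and shows only a limit. No step beyond the scatter is expected, so the estimated change a step that the limit leaves unreadable from compound 2 to compound 4 is essentially none. Compound 4 is expected to give about 100000 nM, within a range from 64000 nM to 250000 nM.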

Compound 4, half-maximal inhibitory concentration: > 64000 nM
Compound 4: no number, only a limit (the forecaster's own chance of this, stated with the estimate: 90%); the middle value is on the limit's open side.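

No step from compound 2 to compound 4 can be read, since each gives only a limit: the limit of > 64000 nM in this assay, at which 4 of the 4 values shown sit.

The compounds shown leave open whether 2,6-difluoropyridin-3-yl in place of 4-fluorophenyl changes cytotoxicity at all.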